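A few compounds are considered here, and "the series" means these few. Any claim that something is new, unique, unknown or untested is made for them only; others in the source may bear on it.

Compound 1 `O=C(CCCCOc1ccccc1)OCC1COCCOCCOCCOCCOCCO1` is known in a functional assay on HBL-100 cells (Homo sapiens) for inhibition, read by sulforhodamine B assay, with a stated time of 48 h (a higher number here means a weaker inhibitor of growth, a lower number a stronger inhibitor of growth), only as a limit, since compound 1 gives > 100000 nM. Compound 2 `O=C(CCCCCc1ccccc1)OCC1COCCOCCOCCOCCOCCO1` gives 64000 nM in this assay. Compound 3 `O=C(CCCc1cc2ccccc2[nH]1)OCC1COCCOCCOCCOCCOCCO1` also reaches only a limit in this assay, giving > 100000 nM. The set is thus shaped by the limit of > 100000 nM in this assay, at which 2 of the 3 values shown sit. Compound 4 `O=C(CCCCC1CCCCC1)OCC1COCCOCCOCCOCCOCCO1` has not been measured; it differs from compound 1 by cyclohexyl in place of phenoxy on a saturated chain carbon, four bonds along the chain from a carbonyl carbon. Among the compounds with values here, the only measured step at that place, an at least 1.5-fold lower number from compound 1 to compound 2 (0.19 log units; that floor lies within the scatter), is a floor that lies within the scatter, so no step beyond the scatter can be read from it. Compound 4 is expected to sit near compound 2. A step of an at least 1.2-fold lower number from compound 1 to compound 4 (0.09 log units; that floor lies within the scatter) is expected. Compound 4 is estimated at 80000 nM, within 40000 nM and 200000 nM.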

Compound 4, concentration for 50% growth inhibition: 72000 nM
Beside the measured number, compound 4's estimate is 1.1-fold (0.05 log units) above it, and the stated range covers the measured number.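

Cyclohexyl and benzyl read alike at this place in this assay, with a 1.1-fold higher number from compound 2 to compound 4 (0.05 log units; within the scatter), so among these compounds an aromatic ring there is not required for a measured value. The comparisons with phenoxy and 1H-indol-2-yl give only floors within the scatter: an at least 1.3-fold lower number from compound 1 to compound 4 (0.14 log units; that floor lies within the scatter), and an at least 1.3-fold lower number from compound 3 to compound 4 (0.14 log units; that floor lies within the scatter). Those two comparisons remain unsettled because they rest on a limit: the limit of > 100000 nM in this assay, at which 2 of the 4 values shown sit.

The compounds shown leave open whether an amine or a carboxylic acid at this place would move the number beyond the scatter. They also leave open what a longer chain would do.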